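This account rests on a few compounds, and the source may have more. Where it says the series, first, only, none or still open, it means among the compounds named here.

Measured compounds in this series:
compound 1 `C=C1[C@@H](C/C=C2/C(=O)OC[C@H]2OC(C)=O)[C@]2(C)CC[C@@H](OC(C)=O)[C@@](C)(CO[Si](C)(C)C(C)(C)C)[C@H]2C[C@@H]1O`: 9790 nM
compound 2 `C=C1[C@@H](OC(C)=O)C[C@@H]2[C@](C)(CO[Si](C)(C)C(C)(C)C)[C@H](OC(C)=O)CC[C@@]2(C)[C@@H]1C[C@@H](Nc1ccccc1F)C1=CCOC1=O`: 4740 nM
compound 3 `C=C1[C@@H](OC(C)=O)C[C@@H]2[C@](C)(CO[Si](C)(C)C(C)(C)C)[C@H](OC(C)=O)CC[C@@]2(C)[C@@H]1C[C@@H](Nc1cccc2ccccc12)C1=CCOC1=O`: 8930 nM

In a functional assay on KB cells (Homo sapiens) for cytotoxicity, read by sulforhodamine B assay (a higher number here means a weaker inhibitor, a lower number a stronger inhibitor), compound 1 carries the highest of the three numbers; compound 3 sits within the scatter of it, while compound 2 lies beyond it. Compound 4 `C=C1[C@@H](OC(C)=O)C[C@@H]2[C@](C)(CO[Si](C)(C)C(C)(C)C)[C@H](OC(C)=O)CC[C@@]2(C)[C@@H]1C/C=C1/C(=O)OC[C@H]1OC(C)=O` differs from compound 1 by acetyl in place of hydrogen on an oxygen on a saturated carbon. Among the compounds with values here, no measured pair shares this change; the single measured step, a 1.9-fold higher number from compound 2 to compound 3 (0.28 log units; within the scatter), concerns an aryl group on an amine nitrogen and says nothing about an acetyl on oxygen. All three measured numbers lie in a narrow band, so for compound 4 no step beyond the scatter is expected, a 1.2-fold lower number from compound 1 to compound 4 (0.09 log units; within the scatter). Compound 4 is therefore estimated at 8000 nM, with a range from 3000 nM to 25000 nM.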

Compound 4, half-maximal inhibitory concentration: 5020 nM
Estimate against measurement, compound 4: 1.6-fold (0.20 log units) above; low and high end bracket the measured number.
By their numbers in this assay, from the lowest: compounds 2, 4, 3 and 1 (each within the scatter of the next, the first and the last beyond it).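

In this assay, within the data shown here, hydroxy to acetoxy on an oxygen on a saturated carbon gives a 2.0-fold lower number from compound 1 to compound 4 (0.29 log units; within the scatter), the first reading of this position. A free hydroxy at this place is therefore not needed for a number in this band. No supporting measurement bears on the reason for this result.

On these data alone, whether a benzoyl ester, a methyl ether or an amine at this place would stay in the same band remains open. Also open, as far as these compounds go, is whether the same change reads alike with the aryl amine of compound 2 present.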